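Pyridinyl Amide Swap on a Shared Core: Expected Potency

The source may hold more compounds than are shown below. What is called first, only, known or untested is meant among the compounds shown, and "the series" means these compounds.

The measured compounds:
compound 1, `NC(=O)c1ccc(-c2cnc(C(=O)CCCCCCc3ccccc3)o2)cc1`; in an assay (Rattus norvegicus) for inhibition of Fatty-acid amide hydrolase 1 (Homo sapiens) (a higher number here means a weaker inhibitor, a lower number a stronger inhibitor), compound 1 gives 10 nM.
compound 2, `Cc1cccnc1-c1cnc(C(=O)CCCCCCc2ccccc2)o1`; in this assay compound 2 gives 15 nM.

Compound 2 holds the higher of the two numbers, with compound 1 nearest to it: a 1.5-fold higher number from compound 1 to compound 2 (0.18 log units; within the scatter), a step within the scatter. Compound 3, `NC(=O)c1cccc(-c2cnc(C(=O)CCCCCCc3ccccc3)o2)n1`, has not yet been measured in this assay. It differs from compound 2 by 6-carbamoylpyridin-2-yl in place of 3-methylpyridin-2-yl on an aromatic carbon. For the measured compounds named here, the only measured step that bears on this change is the one from compound 1 to compound 2, which exchanged 4-carbamoylphenyl for 3-methylpyridin-2-yl and gave a 1.5-fold higher number from compound 1 to compound 2 (0.18 log units; within the scatter). Compound 3 carries both a six-membered aromatic ring with 1 hetero atom and a carbamoyl group, each already present in one of the measured compounds, so no step beyond the scatter is expected in this assay. Compound 3 is therefore estimated at 12 nM, within 4 nM to 40 nM. This corresponds to an expected step of a 1.3-fold lower number from compound 2 to compound 3 (0.10 log units; within the scatter).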

Compound 3, inhibition constant: 1 nM
Beside the measured number, compound 3's estimate is 12-fold (1.08 log units) above it, and the stated range ends above it.
By their numbers in this assay, from the lowest: compound 3; then compounds 1 and 2 (each within the scatter of the next).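

In this assay, the position next to the ring oxygen proved far from indifferent to its substituent: the earlier exchange stayed within the scatter, whereas 6-carbamoylpyridin-2-yl gave a 15-fold lower number from compound 2 to compound 3 (1.18 log units; beyond the scatter) and, against 4-carbamoylphenyl, a 10-fold lower number from compound 1 to compound 3 (1.00 log units; beyond the scatter). Neither the carbamoyl group on a benzene ring in compound 1 nor the pyridine ring bearing methyl in compound 2 matched compound 3, so among these compounds the gain appears only where the pyridine ring and the carbamoyl group occur together in the 6-carbamoylpyridin-2-yl arrangement. No available evidence bears on what lies behind this gain.

The compounds shown leave open whether a carboxylic acid, a methyl ester or a nitrile in place of the carbamoyl group on the same pyridine ring would keep this number. They also leave open whether the gain would survive a shorter or longer chain between the carbonyl and the phenyl ring.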